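The source may hold more compounds than are shown below. What is called first, only, known or untested is meant among the compounds shown, and "the series" means these compounds.

Measured compounds:
compound 1 `Nc1nc2ccccc2c(=O)o1`: > 62500 nM
compound 2 `O=c1oc(Nc2ccccc2I)nc2ccccc12`: 3500 nM
compound 3 `O=c1oc(Nc2c(Cl)cccc2Cl)nc2ccccc12`: 900 nM

All three were tested in an assay on isolated protein for inhibition of complement C1r subcomponent (Homo sapiens); on this read-out higher numbers stand for weaker inhibition and lower numbers for stronger inhibition. For compound 1 the value is a limit of the assay and not a number, so compound 1 stands at the limit of > 62500 nM in this assay, at which 1 of the 3 values shown sits, and only a range is known for it. Compound 2 gives 3500 nM in this assay and compound 3 gives 900 nM; each carries a substituted aromatic ring on the nitrogen that in compound 1 bears only hydrogen. Compound 4 `O=c1oc(Nc2nncs2)nc2ccccc12` has not yet been measured; it differs from compound 1 by 1,3,4-thiadiazol-2-yl in place of hydrogen on a nitrogen on an aromatic ring. Within the data shown here, no step between measured compounds is available, so the expected size is judged from compound 2 and compound 3. Since compound 2 reaches 3500 nM with a ring on that nitrogen, compound 4 is expected to gain, with an at least 10-fold lower number from compound 1 to compound 4 (1.01 log units; beyond the scatter). Compound 4 is estimated at 6000 nM, with a range from 1200 nM to 40000 nM.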

Compound 4, half-maximal inhibitory concentration: > 62500 nM
Compound 4 ended at the assay's limit; the forecaster's own chance of this, stated with the estimate: 25%; middle value at least 10-fold (1.01 log units) from the limit.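

Compound 1 and compound 4 both sit at a limit of the assay and not at a number, so no step between them can be read: the limit of > 62500 nM in this assay, at which 2 of the 4 values shown sit.

The compounds shown leave open whether 1,3,4-thiadiazol-2-yl in place of hydrogen changes inhibition at all.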